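The source may report more compounds than this note shows. Statements on the series, on what has been measured and on what is new or still open speak of the compounds shown alone.

Working notes on the series.

Of the compounds shown here, two have been measured in a physicochemical assay for metabolic stability, read by HPLC; a higher number here means that the compound lasts longer, a lower number that the compound disappears faster. Compound 1, `Cc1cn([C@H]2C[C@H](N=[N+]=[N-])[C@@H](COP(=O)(O)Oc3cccnc3Cl)O2)c(=O)[nH]c1=O`, gives 16.3 h in this assay. Compound 2, `O=c1ccn([C@H]2CC[C@@H](COP(=O)(O)Oc3ccccc3)O2)c(=O)[nH]1`, gives 25.1 h in this assay. Compound 1 holds the lower of the two numbers, but the gap to compound 2 lies within the scatter of repeated measurements, so no order between the two can be read from these values. Going by the values given here, the two compounds also differ in more than one place, so no single step between measured compounds is available to calibrate the effect of any one change.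

The next compound, compound 3, `Cc1cn([C@H]2C[C@H](N=[N+]=[N-])[C@@H](COP(=O)(O)Oc3ccc(Cl)cc3Cl)O2)c(=O)[nH]c1=O`, differs from compound 1 at the oxygen attached to phosphorus: 2,4-dichlorophenyl in place of 2-chloropyridin-3-yl on an oxygen. Nothing measured here shows what this change does in this assay. Given that, the expectation is a step of a 1.2-fold lower number from compound 1 to compound 3 (0.07 log units; within the scatter), which is a small change in either direction, most likely within the scatter. For compound 3 the estimate in this assay is 14 h, with a range from 6 h to 35 h.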

Compound 3, half-life: 3.03 h
Compound 3: middle estimate off by 4.6-fold (0.66 log units), on the high side; the whole stated range lies above it.
By their numbers in this assay, from the lowest: compound 3; then compounds 1 and 2 (each within the scatter of the next).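

The group on the oxygen attached to phosphorus can move the half-life: with the rest of compound 1 unchanged, 2,4-dichlorophenyl in place of 2-chloropyridin-3-yl gives, in this assay, a 5.4-fold lower number from compound 1 to compound 3 (0.73 log units; beyond the scatter) and this step lies beyond the scatter. The earlier pair could not show this, as those two compounds differ in more than one place and their values lie within the scatter of each other. No measured information on either group accounts for the step.

The change replaces a ring with one hetero atom by a ring of carbon only and also brings a second chlorine, so this single step cannot separate the two differences, and a group with only one of them would be needed to do so. Also open, as far as these compounds go, are how an amine, a carboxylic acid or a nitrile on the ring at this oxygen would read in this assay and whether a step of this size would recur on the core of compound 2.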